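Adding a Second Fluoro to Compound 2

This account rests on a few compounds, and the source may have more. Where it says the series, first, only, none or still open, it means among the compounds named here.

Compound 1 `C=CC(=O)Nc1cccc(Nc2nc(N/N=C/c3ccc(F)cc3)ncc2Cl)c1`: 6340 nM in an ADME assay on HT-29 cells (Homo sapiens) for inhibition, read by MTT assay, with a stated time of 72 h; on this read-out lower numbers stand for stronger inhibition and higher numbers for weaker inhibition
Compound 2 `C=CC(=O)Nc1cccc(Nc2nc(N/N=C/c3ccccc3F)ncc2Cl)c1`: 3500 nM in this assay

Compound 2 holds the lower of the two numbers, but the step of a 1.8-fold lower number from compound 1 to compound 2 (0.26 log units; within the scatter) lies within the scatter, so the two compounds are not separated. Compound 3 `C=CC(=O)Nc1cccc(Nc2nc(N/N=C/c3ccc(F)cc3F)ncc2Cl)c1` differs from compound 2 by fluoro in place of hydrogen on an aromatic carbon. Going by the values given here, no measured step adds a second fluoro; the one measured step only moves a single fluoro between positions, and compound 1 shows that a fluoro at that position gives 6340 nM. Compound 3 is therefore expected to show a 1.1-fold higher number from compound 2 to compound 3 (0.06 log units; within the scatter), no change beyond the scatter. The estimate for compound 3 is 4000 nM, ranging from 1500 nM to 11000 nM.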

Compound 3, half-maximal inhibitory concentration: 4760 nM
Estimate against measurement, compound 3: 1.2-fold (0.08 log units) below; the range from low to high includes it.
By their numbers in this assay, from the lowest: compounds 2, 3 and 1 (each within the scatter of the next).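

In this assay, the change from 2-fluorophenyl to 2,4-difluorophenyl is a 1.4-fold higher number from compound 2 to compound 3 (0.13 log units; within the scatter), and the change from 4-fluorophenyl to 2,4-difluorophenyl is a 1.3-fold lower number from compound 1 to compound 3 (0.12 log units; within the scatter). A second fluoro on this ring therefore leaves compound 3 unseparated from either single-fluoro compound, whichever of the two it is compared with. Nothing available bears on the reason for this result. The compounds shown leave open whether a group other than fluoro, such as an amine or a carboxylic acid, on this aromatic carbon para to the large group would give a step beyond the scatter.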